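Replacing the phenylpyrrolidine in compound 2 with a bicyclic amine

A few compounds are considered here, and "the series" means these few. Any claim that something is new, unique, unknown or untested is made for them only; others in the source may bear on it.

The three measured compounds share a common core that carries an amide on one side and an amine on the other. Compound 1 `CC(C)N(C)c1ccc2cc(NC(=O)CCc3ccc(C(F)(F)F)cc3)ccc2n1` has an isopropyl(methyl)amino group at the amine position and gives 140 nM in a functional assay on HEK293 cells for activation of melanin-concentrating hormone receptor 1 (Rattus norvegicus), read by inositol phosphate accumulation; on this read-out lower numbers stand for an effect already at smaller amounts and higher numbers for an effect only at larger amounts of compound. Compound 2 `O=C(CCc1ccc(C(F)(F)F)cc1)Nc1ccc2nc(N3CCC(c4ccccc4)C3)ccc2c1` carries a 3-phenylpyrrolidin-1-yl group instead and gives 1770 nM, the highest number of the three; the nearest is compound 1 and the furthest is compound 3 `O=C(CCCCCCCCCCCCc1ccc(C(F)(F)F)cc1)Nc1ccc2nc([N+]34CCC(CC3)CC4)ccc2c1`, which with a much longer chain and a charged bicyclic amine gives 25 nM. Compound 4 `O=C(CCc1ccc(C(F)(F)F)cc1)Nc1ccc2nc(N3CC4CCC3CC4)ccc2c1` is not yet measured. Its change from compound 2 is a group of 8 heavy atoms (7 carbon, 1 nitrogen; 2 six-membered non-aromatic rings with 1 hetero atom each) in place of a group of 11 heavy atoms (10 carbon, 1 nitrogen; one five-membered non-aromatic ring with 1 hetero atom, one six-membered aromatic ring of carbon only), on an aromatic carbon.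

Going by the values given here, only one measured step bears on this position: a 13-fold higher number from compound 1 to compound 2 (1.10 log units; beyond the scatter), which shows that moving from a small acyclic amine to the larger phenyl-bearing ring raised the number considerably. Compound 4 goes back to a smaller amine, though a bicyclic one. A step toward lower numbers is therefore expected, likely of moderate size, so compound 4 is estimated at 250 nM with a range of 60 nM to 900 nM, that is an expected step of a 7.1-fold lower number from compound 2 to compound 4 (0.85 log units; beyond the scatter).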

Compound 4, half-maximal effective concentration: 190 nM
Compound 4: the middle estimate sits 1.3-fold (0.12 log units) above what was measured, within the range that was stated.
By their numbers in this assay, from the lowest: compound 3; then compounds 1 and 4 (each within the scatter of the next); then compound 2.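

Compared with the 3-phenylpyrrolidin-1-yl group, the bicyclic amine with its two six-membered non-aromatic rings gives a 9.3-fold lower number from compound 2 to compound 4 (0.97 log units; beyond the scatter) in this assay at this position, next to the ring nitrogen. Set against the open-chain isopropyl(methyl)amino group, the same amine gives a 1.4-fold higher number from compound 1 to compound 4 (0.13 log units; within the scatter) and so cannot be told apart from it, which means that a ring system larger than the small open-chain group does not by itself go with a high number; among these three amines, only the 3-phenylpyrrolidin-1-yl group of compound 2 stands apart. No measurement shown here explains why these groups differ in this way.

Still open, on these data alone, is whether the phenyl ring or the five-membered ring goes with the high number of compound 2, a question that plain pyrrolidine would help to answer, and whether piperidine or morpholine would fall with compound 2 or with the other two. Compound 3 differs from compound 4 in both its chain and its amine, so a longer chain joined to the amine of compound 4 would be needed to separate those two changes.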